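Swapping phenyl for hydrogen on the ring nitrogen

A few compounds are considered here, and "the series" means these few. Any claim that something is new, unique, unknown or untested is made for them only; others in the source may bear on it.

Among the compounds with values here, in a functional assay on K562 cells (Homo sapiens) for antiproliferative activity, read by MTT assay, with a stated time of 48 h (a higher number here means a weaker inhibitor, a lower number a stronger inhibitor), compound 1 (`Cn1cc(C2=C(c3nn(CCn4ccnc4)c4ncccc34)C(=O)N(c3ccccc3)C2=O)c2ccccc21`) gives 26400 nM as the second highest of three numbers so far. Compound 3 (`Cn1cc(C2=C(c3nn(CCCCn4ccnc4)c4ncccc34)C(=O)NC2=O)c2ccccc21`) gives 31800 nM and so lies within the scatter of compound 1, while compound 2 (`CN(C)CCCn1nc(C2=C(c3cn(C)c4ccccc34)C(=O)N(c3ccccc3)C2=O)c2cccnc21`) gives 1700 nM on the same scale. Within the data shown here, the one measured step is a 16-fold lower number from compound 1 to compound 2 (1.19 log units; beyond the scatter) and lies beyond the scatter, but it comes from (dimethylamino)methyl in place of 1H-imidazol-1-yl on the chain, not from the change followed here.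

Compound 4 (`Cn1cc(C2=C(c3nn(CCn4ccnc4)c4ncccc34)C(=O)NC2=O)c2ccccc21`) keeps the chain of compound 1 and differs from it (hydrogen in place of phenyl on an amide-type nitrogen in a ring) by hydrogen in place of phenyl on an amide-type nitrogen in a ring. Among the measured compounds shown here, no measured step isolates this change. The closest guide is compound 3, which also has hydrogen on that nitrogen but a different chain, and whose 31800 nM sits within the scatter of compound 1. No step beyond the scatter is therefore expected in this assay here. The expected change is a 1.2-fold lower number from compound 1 to compound 4 (0.08 log units; within the scatter) on this thin evidence. For compound 4 the estimate is 22000 nM with 8000 nM to 50000 nM as the expected range.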

Compound 4, half-maximal inhibitory concentration: > 100000 nM
Compound 4 was reported as a limit; the forecaster's own chance of this, stated with the estimate: 10%; at least 4.5-fold (0.65 log units) between middle value and limit.
By their numbers in this assay, from the lowest: compound 2; then compounds 1 and 3 (each within the scatter of the next). At a limit, above all of these: compound 4.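

In this assay the reading for compound 4 is a limit of the assay and not a number: the limit of > 100000 nM in this assay, at which 1 of the 4 values shown sits. Hydrogen in place of phenyl on the amide-type nitrogen gives an at least 3.7-fold higher number from compound 1 to compound 4 (0.57 log units; beyond the scatter), the first direct sign that the group at this position matters, though this is shown only with the 2-(1H-imidazol-1-yl)ethyl-type chain of these two compounds. With hydrogen on that nitrogen in both, 1H-imidazol-1-yl in place of 2-(1H-imidazol-1-yl)ethyl on a saturated chain carbon gives an at least 3.1-fold higher number from compound 3 to compound 4 (0.49 log units; beyond the scatter), so the chain also counts here.

As far as these compounds go, both steps are lower bounds, and their true sizes stay unknown. Also open, from the compounds shown here alone, are how a methyl or benzyl group on that nitrogen would read, and whether hydrogen there has a similar effect with the dimethylamino chain of compound 2.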